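The compounds below may be only part of what the source reports. "The series", "measured", "known", "first", "only" and "open" are said of these compounds alone.

Measured so far in a physicochemical assay for solubility, read by spectrophotometry, with a stated time of 24 h, at pH 7.4; a lower number here means a less soluble compound, a higher number a more soluble compound:
Compound 1, `COC(=O)c1cccc(/C=N/NC(=O)c2ccc(N(C)C)cc2)c1` — 3700 nM.
Compound 2, `COC(=O)c1cccc(/C=N/N(C)C(=O)c2ccc(N(C)C)cc2)c1` — 8200 nM.
Compound 3, `CN(C)c1ccc(C(=O)N/N=C/c2ccc(C(=O)O)cc2)cc1` — only a limit of this assay, > 77000 nM.

Compound 4, `CN(/N=C/c1ccc(C(=O)O)cc1)C(=O)c1ccc(N(C)C)cc1`, has not yet been measured in this assay. How the core of compound 1 differs from the core of compound 3 is not broken down here. Within the measured pair the change is methyl in place of hydrogen on an amide-type nitrogen, and it gave a 2.2-fold higher number from compound 1 to compound 2 (0.35 log units; beyond the scatter). The same kind of change leads from compound 3 to compound 4: methyl in place of hydrogen on an amide-type nitrogen; the surroundings of the place read the same in both cases. For compound 3 the value is a limit, and the one observation bearing on this, (the limit of > 77000 nM in this assay, at which 1 of the 3 values shown sits), records that it sits there. A step of about the size of the measured one is expected, a step that the limit leaves unreadable from compound 3 to compound 4. That expectation rests on compound 2 and its 8200 nM set beside compound 1. For compound 4 the estimated value in this assay is 120000 nM, between 50000 nM and 300000 nM, and it is expected that the assay will most likely again report only a limit.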

Compound 4, solubility: > 67000 nM
Compound 4 was reported as a limit (the forecaster's own chance of this, stated with the estimate: 75%); the middle value is on the limit's open side.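

In this assay compound 3 gives > 77000 nM, which is a limit of the assay. Among the compounds shown here, compound 4 gives > 67000 nM, also a limit, so no step between compound 3 and compound 4 can be read. The compounds shown leave open whether methyl in place of hydrogen on an amide-type nitrogen changes the number on the core of compound 3 at all.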